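Notes on compound 1 and the 3-chlorophenyl analogue

The source may report more compounds than this note shows. Statements on the series, on what has been measured and on what is new or still open speak of the compounds shown alone.

Measured so far:
- compound 1, `CC(C(=O)N1CCN(c2ccc(Cl)cc2)CC1)N1C(=O)CCC1=O`: in a functional assay on the whole organism (strain Swiss) with Mus musculus as the target, in the maximal electroshock model, with a stated time of 0.25 h, at a dose of 300 mg/kg by the intraperitoneal route (on this read-out higher numbers stand for a stronger effect at the one dose given and lower numbers for a weaker effect), compound 1 gives 100%
- compound 2, `CCC(C(=O)N1CCN(c2cccc(OC)c2)CC1)N1C(=O)CCC1=O`: compound 2 gives 25%
- compound 3, `CCC(C(=O)N1CCN(c2ccccc2C(F)(F)F)CC1)N1C(=O)CCC1=O`: compound 3 gives 25%

Compound 1 stands highest of the three numbers. Compound 2 and compound 3 both lie well below it, each by a gap beyond the usual scatter, and the two of them sit at the same value as each other. Among the measured compounds shown here, no step between two measured compounds that differ in a single place is available, so none of these gaps can be tied to one structural change; compound 2 and compound 3 differ from compound 1 in more than one place.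

The next compound is compound 4, `CC(C(=O)N1CCN(c2cccc(Cl)c2)CC1)N1C(=O)CCC1=O`, which differs from compound 1 in one place: 3-chlorophenyl in place of 4-chlorophenyl on an amine nitrogen in a ring.

For the measured compounds named here, with no single-change step on record, the direction of this change is open. Since compound 1 already gives 100% in this assay, there is no room for a rise, and a step downward of moderate size is expected, a number 25 percentage points lower from compound 1 to compound 4 (beyond the scatter). For compound 4 the estimate is 75%, in the range 40% to 100%, and the reading is expected to be a number rather than a limit.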

Compound 4, a percentage reported as activity, at one dose (the size of the read-out at that dose, not a potency): 75%
The estimate for compound 4 equals the measured number at the digits printed, within the range that was stated.
By their numbers in this assay, from the lowest: compounds 2 and 3 (each within the scatter of the next); then compound 4; then compound 1.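

In this assay, among the compounds shown here, the change from 4-chlorophenyl to 3-chlorophenyl gives a number 25 percentage points lower from compound 1 to compound 4 (beyond the scatter) and is the first step that can be tied to a single structural change. The two compounds have the same atoms joined differently, so the place of the chlorine on the phenyl ring alone is enough to shift this read-out, while compound 4 still keeps a sizeable effect at the one dose given, with 75% as its value. The data at hand offer no explanation for this shift.

Going by these compounds, what the chlorine itself contributes remains open, since both members of this pair carry it and neither shows how an unsubstituted phenyl or a bromine in its place would read. One pair at a single dose and a single time also leaves open whether the step reflects a lasting difference between the two compounds, and whether the same change would give a step of similar size on the other side chains in the series.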